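The source may report more compounds than this note shows. Statements on the series, on what has been measured and on what is new or still open speak of the compounds shown alone.

Series notes, amide side chain of the shared core.

Three compounds of the series carry a number in an assay on THP-1 cells for displacement of a labelled ligand from C-C chemokine receptor type 1 (Homo sapiens); a higher number here means a weaker inhibitor, a lower number a stronger inhibitor. Compound 1 `CC(C)[C@@H](NC(=O)c1cc2ccccc2s1)C(=O)N1CCC(c2ccc(Cl)cc2)CC1` gives 58 nM in this assay, the lowest of the three. Compound 3 `O=C(N[C@@H](C(=O)N1CCC(c2ccc(Cl)cc2)CC1)C1CCCCC1)c1ccccc1` gives 121 nM in this assay, and compound 2 `CC(C)C(NC(=O)Oc1ccccc1)C(=O)N1CCC(c2ccc(Cl)cc2)CC1` gives 265 nM in this assay. Both gaps to compound 1 lie beyond the usual scatter, so compound 1 stands as the strongest inhibitor of the three measured. For the measured compounds named here, no pair among the three differs in only one place, so no single step can be read from the measured set; compounds 2 and 3 differ from compound 1 at the amide substituent and elsewhere, and their values are noted only as they stand.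

Compound 4 `CC(C)[C@@H](NC(=O)CC1CC1)C(=O)N1CCC(c2ccc(Cl)cc2)CC1` is not yet measured in this assay. It differs from compound 1 as follows: cyclopropylmethyl in place of 1-benzothiophen-2-yl on a carbonyl carbon. The 1-benzothiophen-2-yl group of compound 1 is the largest amide substituent in the measured set, and it goes with the lowest number, so a loss of potency is expected on its removal. The step from compound 1 to compound 4 is estimated to be an 8.6-fold higher number from compound 1 to compound 4 (0.94 log units; beyond the scatter) in this assay, clearly beyond the scatter. For compound 4 the expected value in this assay is 500 nM, with a range from 150 nM to 2000 nM.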

Compound 4, half-maximal inhibitory concentration: 46 nM
Compound 4: middle estimate off by 11-fold (1.04 log units), on the high side; the measured number lies below the stated range.
By their numbers in this assay, from the lowest: compounds 4 and 1 (each within the scatter of the next); then compound 3; then compound 2.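

For the compounds shown here, the step of a 1.3-fold lower number from compound 1 to compound 4 (0.10 log units; within the scatter) in this assay is the first single-place comparison, and it shows that the 1-benzothiophen-2-yl group is not needed on this carbonyl carbon to keep the number at this level. Cyclopropylmethyl, with 4 heavy atoms against 9 and no aromatic ring, cannot be told apart from the larger group in this read-out, so within this pair neither the size of the substituent nor an aromatic ring at this place sets the number. No data on hand explain why the two groups give such similar numbers.

Still open, as far as these compounds go, is how far this place tolerates change: whether a longer carbon chain, a plain phenyl ring, an amine or a carboxylic acid on this carbonyl carbon would stay level with compound 4. Going by these compounds alone, also open is whether cyclopropylmethyl holds up when other parts of the molecule change, since compound 2 and compound 3 each differ from compound 4 in more than one place and give no step on this.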